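This account rests on a few compounds, and the source may have more. Where it says the series, first, only, none or still open, it means among the compounds named here.

In an ADME assay on the whole organism (blood, Mus musculus, strain C57BL/6) for pharmacokinetics, read by HPLC, with a stated time of 4 h, at a dose of 2 mg/kg by the intraperitoneal route (a higher number here means more compound in the circulation at the dose given, a lower number less compound in the circulation), compound 1 (`O=C(Nc1ccc(Cl)c(C(=O)N2CCCCC2)c1O)Nc1cccc(F)c1Cl`) gives "below limit of detection" (no number reported). Compound 2 (`CN1CCN(S(=O)(=O)c2c(Cl)ccc(NC(=O)Nc3cccc(Cl)c3Cl)c2O)CC1`) gives 303 ng.h/mL and compound 3 (`CN1CC[C@H](S(=O)(=O)c2c(Cl)ccc(NC(=O)Nc3cccc(F)c3Cl)c2O)C1`) gives 432 ng.h/mL. These two numbers lie within the scatter of each other, so compound 3 stands level with compound 2. Compound 4 (`CN1CCC2(CC1)CC(S(=O)(=O)c1c(Cl)ccc(NC(=O)Nc3cccc(F)c3Cl)c1O)C2`) differs from compound 3 on a sulfonyl sulfur: a group of 10 heavy atoms (9 carbon, 1 nitrogen; one four-membered non-aromatic ring of carbon only, one six-membered non-aromatic ring with 1 hetero atom) in place of a group of 6 heavy atoms (5 carbon, 1 nitrogen; one five-membered non-aromatic ring with 1 hetero atom), on a sulfonyl sulfur. Among the measured compounds shown here, no measured pair differs in one place, so the data offer no direct guide to this change. A step of a 1.3-fold lower number from compound 3 to compound 4 (0.12 log units; within the scatter) is expected in this assay, with nothing expected beyond the scatter in either direction. The estimated value for compound 4 is 330 ng.h/mL, with an expected range of 120 ng.h/mL to 900 ng.h/mL.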

Compound 4, area under the concentration-time curve: 1390 ng.h/mL
For compound 4 the middle estimate is 4.2-fold (0.62 log units) below the measured one, outside the stated range (above it).
By their numbers in this assay, from the lowest: compounds 2 and 3 (each within the scatter of the next); then compound 4.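

In this assay, putting the group of 10 heavy atoms in place of 1-methylpyrrolidin-3-yl on the sulfonyl sulfur gives a 3.2-fold higher number from compound 3 to compound 4 (0.51 log units; beyond the scatter). Among the compounds shown here, this is the only single-place step, and it shows that the group on the sulfonyl sulfur can move the number beyond the scatter. No measurement at hand accounts for the step.

As far as these compounds go, it remains open whether the four-membered carbon ring, the six-membered ring or the overall group size carries the step. From the compounds shown here alone, it is also open how an unsubstituted piperidine or a carboxylic acid would read at this place.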